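Swapping an Ethoxy for Chloro Beside the Amide

The source may hold more compounds than are shown below. What is called first, only, known or untested is meant among the compounds shown, and "the series" means these compounds.

Of the compounds shown here, two have been measured in an assay on cells for inhibition of MAP kinase-interacting serine/threonine-protein kinase 1 (Homo sapiens), read by mobility shift assay, with stated times of 10 min and 60 min, in the presence of a further agent that is not named here; a higher number here means a weaker inhibitor, a lower number a stronger inhibitor. Compound 1 `CCOc1cc(-c2cccnc2)ccc1C(N)=O` gives 2200 nM, the lowest of the two numbers. Compound 2 `Nc1snnc1-c1ccc(C(F)(F)F)cc1` gives 50000 nM, a number higher than that of compound 1 by a gap beyond the scatter; the two structures differ in more than one place, so their values are simply set side by side. Compound 3 `NC(=O)c1ccc(-c2cccnc2)cc1Cl` has not yet been measured. It differs from compound 1 in one place: chloro in place of ethoxy on an aromatic carbon. For the measured compounds named here, no measured pair shows what this exchange does, so the expectation rests on compound 1 alone. The expected step of a 1.8-fold higher number from compound 1 to compound 3 (0.26 log units; within the scatter) is modest and toward a weaker inhibitor, though it may well fall within the scatter. For compound 3 the estimate is 4000 nM, with a range from 1000 nM to 15000 nM.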

Compound 3, half-maximal inhibitory concentration: 11000 nM
Compound 3: the middle estimate sits 2.8-fold (0.44 log units) below what was measured, and the stated range covers the measured number.
By their numbers in this assay, from the lowest: compound 1; then compound 3; then compound 2.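

In this assay, chloro in place of ethoxy ortho to the carbamoyl group gives a 5.0-fold higher number from compound 1 to compound 3 (0.70 log units; beyond the scatter), so this exchange yields a weaker inhibitor and the position responds to a change of group. The ethoxy brings three heavy atoms and a hydrogen-bond acceptor, whereas the chloro brings one heavy atom and no acceptor, but a single step cannot separate these differences. Nothing available explains why the number rises.

As far as these compounds go, it remains open what a methoxy group, a longer chain such as propoxy, or an amine would give at this same place, and so whether size or the oxygen atom is what matters here. Also open, from the compounds shown here alone, is whether the exchange would have a similar effect on a core other than that of compound 1.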